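The compounds below may be only part of what the source reports. "The series", "measured", "known", "first", "only" and "open" are said of these compounds alone.

Within the data shown here, compound 2 `C[C@H]1CC[C@@H]2[C@@H](OC(=O)[C@]23CC(c2ccccc2Br)=NO3)[C@]2(C)C(=O)C=C[C@@]12O` holds the lowest of the two numbers so far in a physicochemical assay for lipophilicity (on this read-out lower numbers stand for lower lipophilicity and higher numbers for higher lipophilicity), where compound 2 gives 2.22; compound 1 `C[C@H]1CC[C@@H]2[C@@H](OC(=O)[C@]23CC(c2c(Cl)cccc2Cl)=NO3)[C@]2(C)C(=O)C=C[C@@]12O` gives 2.67. Among the measured compounds shown here, the only measured step is a number 0.45 log units lower from compound 1 to compound 2 (beyond the scatter). Compound 3 `C[C@H]1CC[C@@H]2[C@@H](OC(=O)[C@]23CC(c2cccc([N+](=O)[O-])c2)=NO3)[C@]2(C)C(=O)C=C[C@@]12O` differs from compound 2 by 3-nitrophenyl in place of 2-bromophenyl on a carbon with a double bond to nitrogen. For the measured compounds named here, no measured step covers this exact exchange; the single step on hand shows only that changing the group on the carbon with a double bond to nitrogen moves this assay by a modest amount. A fall beyond the scatter is expected, estimated as a number 0.82 log units lower from compound 2 to compound 3 (beyond the scatter). Compound 3 is expected to give 1.4, with a range from 0.9 to 1.9.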

Compound 3, partition coefficient: 1.37
For compound 3 the middle estimate is 0.03 log units above the measured one; low and high end bracket the measured number.
By their numbers in this assay, from the lowest: compound 3; then compound 2; then compound 1.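

In this assay, 3-nitrophenyl on the carbon with a double bond to nitrogen gives a number 0.85 log units lower from compound 2 to compound 3 (beyond the scatter), and a number 1.30 log units lower from compound 1 to compound 3 (beyond the scatter). This position therefore spans a wider range than the two halogen-bearing phenyl groups showed, with the group carrying 2 hydrogen-bond acceptors at the lowest number. No evidence on hand bears on the origin of this change. Open, on these data alone, is whether an aminophenyl or a phenyl bearing a carboxylic acid would extend the range, and whether the fall follows the nitro group or its place on the phenyl ring.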